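The source may hold more compounds than are shown below. What is called first, only, known or untested is meant among the compounds shown, and "the series" means these compounds.

In a functional assay on HCT-15 cells (Homo sapiens) for inhibition, read by MTT assay, with a stated time of 72 h (a lower number here means a stronger inhibitor, a higher number a weaker inhibitor), three compounds sharing one core have been measured. Compound 1 `COc1ccc(CNCc2c(OC)cc(Oc3cccc(Nc4ccccc4)c3)cc2OC)cc1` gives 2650 nM, compound 2 `COc1cc(Oc2cccc(Nc3ccccc3)c2)cc(OC)c1CNCCNC(C)=O` gives 5090 nM and compound 3 `COc1cc(Oc2cccc(Nc3ccccc3)c2)cc(OC)c1CN[C@H](C)c1ccccc1` gives 7550 nM. Compound 2 lies inside the span set by the other two and within the scatter of each, the steps being a 1.9-fold higher number from compound 1 to compound 2 (0.28 log units; within the scatter) and a 1.5-fold higher number from compound 2 to compound 3 (0.17 log units; within the scatter). Only a 2.8-fold higher number from compound 1 to compound 3 (0.45 log units; beyond the scatter) passes beyond the scatter, and it is modest.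

Compound 4 `COc1cc(Oc2cccc(Nc3ccccc3)c2)cc(OC)c1CCO` differs from compound 2 by one change, hydroxymethyl in place of (2-acetamidoethyl)amino on a saturated chain carbon bound to an aromatic carbon. Among the compounds with values here, each measured step exchanges one substituent on the amine nitrogen for another, whereas this change removes that nitrogen, so no measured step matches it directly. With a 2.8-fold higher number from compound 1 to compound 3 (0.45 log units; beyond the scatter) as the largest guide, a small move toward a higher number is expected, though the direction is only weakly supported. The expected change is a 1.6-fold higher number from compound 2 to compound 4 (0.20 log units; within the scatter). Compound 4 is estimated at 8000 nM, with an expected range from 3000 nM to 20000 nM.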

Compound 4, half-maximal inhibitory concentration: 12100 nM
Beside the measured number, compound 4's estimate is 1.5-fold (0.18 log units) below it, within the range that was stated.
By their numbers in this assay, from the lowest: compounds 1, 2, 3 and 4 (each within the scatter of the next, the first and the last beyond it).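

In this assay, within the data shown here, the saturated chain carbon bound to an aromatic carbon carries hydroxymethyl in place of an amino group, the first change here that removes the amine nitrogen instead of exchanging what sits on it. The change gives a 2.4-fold higher number from compound 2 to compound 4 (0.38 log units; beyond the scatter) and a 4.6-fold higher number from compound 1 to compound 4 (0.66 log units; beyond the scatter) as modest steps beyond the scatter, the second being the largest step in the set. Compound 3 goes against this pattern, since a 1.6-fold higher number from compound 3 to compound 4 (0.20 log units; within the scatter) stays within the scatter, so loss of the amine separates compound 4 clearly from only compound 1 and compound 2.

Nothing in the data given explains these steps. On these data alone, it remains open whether a primary amine or a carboxylic acid on this chain carbon would read like the secondary amines or like compound 4.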